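The source may hold more compounds than are shown below. What is called first, only, known or untested is meant among the compounds shown, and "the series" means these compounds.

Among the measured compounds shown here, in a functional assay on the whole organism with Rattus norvegicus as the target (a lower number here means that less compound is needed, a higher number that more compound is needed for the effect), compound 3 `CCCn1c(=N)sc2cc(OC(F)(F)F)ccc21` gives 4.5 mg/kg, the only number among the three values measured so far. Compound 1 `CC(C)(C)Cc1ccc2nc(N)sc2c1` reaches only the limit of > 10 mg/kg in this assay. Compound 2 `CCCCCCCc1ccc2nc(N)sc2c1` likewise reaches only the limit of > 10 mg/kg. Thus (the limit of > 10 mg/kg in this assay, at which 2 of the 3 values shown sit), and compound 3 stands alone as a measured number, with no step between measured compounds to lean on.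

Compound 4 `CCN(CC)C(=O)Cn1c(=N)sc2cc(OC(F)(F)F)ccc21` differs from compound 3 in one place: diethylcarbamoyl in place of ethyl on a saturated chain carbon bound to an aromatic nitrogen. For the measured compounds named here, no measured pair in this assay differs in that way, so the size and direction of the step cannot be read from the data. The change is expected to move the dose in this assay by no more than the usual scatter, with a slight lean toward a higher dose. The estimate for compound 4 is 6 mg/kg, with a range from 2 mg/kg to 20 mg/kg. This estimate means an expected step of a 1.3-fold higher number from compound 3 to compound 4 (0.12 log units; within the scatter) in this assay.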

Compound 4, dose for half-maximal effect: 9 mg/kg
The estimate for compound 4 lay 1.5-fold (0.18 log units) below the measured number; the range from low to high includes it.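

The saturated chain carbon bound to an aromatic nitrogen now has its first readable step in this assay: a 2.0-fold higher number from compound 3 to compound 4 (0.30 log units; within the scatter). The change is large by count, with diethylcarbamoyl bringing 7 heavy atoms and 1 hydrogen-bond acceptor where ethyl had 2 heavy atoms and none, yet the step stays within the scatter, so this place tolerates a much bigger group with a carbonyl without a clear loss in this assay. Nothing measured here gives a cause for the step.

One step at one place cannot show whether the carbonyl or the two ethyl groups of the amide matter more. On these data alone, how a carboxylic acid, an amine or a longer plain alkyl chain would read at this place remains open.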